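This account rests on a few compounds, and the source may have more. Where it says the series, first, only, none or still open, it means among the compounds named here.

Measured compounds in an assay on cells for inhibition of interleukin-5 receptor subunit alpha (Mus musculus), read by WST assay, with a stated time of 48 h, tested at 30 uM, in the presence of a further agent that is not named here; a lower number here means less inhibition, a higher number more inhibition at the concentration tested (going by the name of the read-out):
compound 1 `OCCCNCc1nc2c(OCC3CCCCC3)cccc2[nH]1` gives 52.7%
compound 2 `OCCCCNCc1nc2c(OCC3CCCCC3)cccc2[nH]1` gives 44.3%
compound 3 `CC(C)(CO)NCc1nc2c(OCC3CCCCC3)cccc2[nH]1` gives 54.7%

Among these three, compound 3 is separated from compound 2 by a number 10.4 percentage points higher from compound 2 to compound 3 (beyond the scatter), a step beyond the scatter, whereas the step of a number 2 percentage points higher from compound 1 to compound 3 (within the scatter) places compound 1 within the scatter of compound 3. Compound 4 `OCC(NCc1nc2c(OCC3CCCCC3)cccc2[nH]1)c1ccccc1` differs from compound 3 in one place: 2-hydroxy-1-phenylethyl in place of 1-(hydroxymethyl)-1-methylethyl on an amine nitrogen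

For the measured compounds named here, the steps that bear on this change are a number 2 percentage points higher from compound 1 to compound 3 (within the scatter) and a number 10.4 percentage points higher from compound 2 to compound 3 (beyond the scatter), both exchanges of the substituent on the amine nitrogen; the first within the scatter, the second modest. With a third such exchange, compound 4 is expected to move by no more than the scatter in this assay, in no settled direction, so the expected step is a number 4.7 percentage points lower from compound 3 to compound 4 (within the scatter). Compound 4 is therefore estimated at 50%, between 35% and 65%.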

Compound 4, a percentage reported as inhibition, at one concentration (the size of the read-out at that concentration, not a potency): 77.7%
Compound 4: middle estimate off by 27.7 percentage points, on the low side; measured number outside the range, above it.
By their numbers in this assay, from the lowest: compounds 2, 1 and 3 (each within the scatter of the next, the first and the last beyond it); then compound 4.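

In this assay, the 2-hydroxy-1-phenylethyl group on the amine nitrogen, the only substituent here with a six-membered aromatic ring, gives a number 23 percentage points higher from compound 3 to compound 4 (beyond the scatter) and a number 25 percentage points higher from compound 1 to compound 4 (beyond the scatter) and also a number 33.4 percentage points higher from compound 2 to compound 4 (beyond the scatter). Among the earlier open-chain groups, the largest step was only a number 10.4 percentage points higher from compound 2 to compound 3 (beyond the scatter), so this position can carry a much larger change than they showed. Nothing measured here accounts for the rise.

As far as these compounds go, it remains open whether the aromatic ring itself matters, or whether a saturated ring such as cyclohexyl would serve equally. The role of the hydroxy group in compound 4 is also unsettled, and a plain benzyl group on the amine nitrogen would bear on both questions.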